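The source may report more compounds than this note shows. Statements on the series, on what has been measured and on what is new or still open speak of the compounds shown alone.

Of the compounds shown here, three have so far been measured in an ADME assay on RAW264.7 cells (Mus musculus) for cytotoxicity, with a stated time of 24 h; on this read-out higher numbers stand for weaker inhibition and lower numbers for stronger inhibition. Compound 1 `N#Cc1c(-c2c[nH]c3ccccc23)cc(-c2ccc3c(c2)CCCC3)[nH]c1=O` is reported only as a limit, > 100000 nM, which is the limit of > 100000 nM in this assay, at which 1 of the 3 values shown sits. Compound 2 `COc1ccc(-c2cc(-c3ccc4c(c3)CCCC4)nc(NCc3ccccc3)c2C#N)cc1OC` gives 4900 nM. Compound 3 `CC(C)c1ccc(-c2cc(-c3ccc4c(c3)CCCC4)nc(NCc3ccccc3)c2C#N)cc1` is likewise reported only as a limit, > 50000 nM. For the measured compounds named here, the single measured step, an at least 10-fold higher number from compound 2 to compound 3 (1.00 log units; beyond the scatter), runs into the limit of > 50000 nM in this assay, at which 1 of the 3 values shown sits, and so has no upper bound of its own. Compound 4 `CC(C)c1ccc(-c2cc(-c3ccc4c(c3)CCCC4)nc(OCC(=O)NN)c2C#N)cc1` differs from compound 3 by (aminocarbamoyl)methoxy in place of benzylamino on an aromatic carbon. No measured step touches that position, and nothing shown points to a direction. Compound 3 already stands at the limit > 50000 nM. Compound 4 is therefore expected to stay weak, the expected step being a step that the limit leaves unreadable from compound 3 to compound 4, quite possibly another limit. The estimate for compound 4 is 60000 nM, between 15000 nM and 200000 nM.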

Compound 4, half-maximal inhibitory concentration: 27700 nM
Beside the measured number, compound 4's estimate is 2.2-fold (0.34 log units) above it; measured number inside the range.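

Putting (aminocarbamoyl)methoxy in place of benzylamino, next to the ring nitrogen, gives an at least 1.8-fold lower number from compound 3 to compound 4 (0.25 log units; that floor lies within the scatter) in this assay. Compound 3 is reported only as a limit, > 50000 nM, so the real size of this change cannot be read. The step does show that a group with no ring at this position still gives a measured number alongside the 4-isopropylphenyl group.

Open, as far as these compounds go, is whether a carboxylic acid, a plain methoxy or a longer chain here would give a different number. Also open, from the compounds shown here alone, is how this replacement would behave with the 3,4-dimethoxyphenyl group of compound 2.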